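Removing the Aromatic Nitrogen Methyl from Compound 3

The source may hold more compounds than are shown below. What is called first, only, known or untested is meant among the compounds shown, and "the series" means these compounds.

For the measured compounds named here, compound 3 `COc1cccc(-c2cc(-c3cc4ccccc4n3C)no2)c1` is the only member of the set with an actual number in a functional assay on COLO 320 cells (Homo sapiens) for cytotoxicity, read by WST assay, with a stated time of 72 h (a lower number here means a stronger inhibitor, a higher number a weaker inhibitor), where compound 3 gives 69500 nM. Compound 1 `Cn1c(-c2cc(-c3cccc(F)c3)on2)cc2ccccc21` reaches only a limit of the assay, > 100000 nM. Compound 2 `COc1cccc(-c2cc(-c3cc4cc(OC)ccc4[nH]3)no2)c1` likewise stops at a limit, > 100000 nM. Going by the values given here, the single measured step, an at least 1.4-fold lower number from compound 1 to compound 3 (0.15 log units; that floor lies within the scatter), is anchored on a limit, since the limit of > 100000 nM in this assay, at which 2 of the 3 values shown sit, marks where compound 1 sits. Compound 4 `COc1cccc(-c2cc(-c3cc4ccccc4[nH]3)no2)c1` differs from compound 3 by hydrogen in place of methyl on an aromatic nitrogen. Among the compounds with values here, no measured step covers this change; compound 2 carries the same hydrogen on that nitrogen together with a further methoxy and shows only a limit. Compound 4 is therefore expected to weaken rather than improve, an expected step of a 1.7-fold higher number from compound 3 to compound 4 (0.24 log units; within the scatter). The estimate for compound 4 in this assay is 120000 nM, within 40000 nM to 400000 nM, with a fair chance that only a limit is reported.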

Compound 4, half-maximal inhibitory concentration: > 100000 nM
Compound 4: a limit, no number; the forecaster's own chance of this, stated with the estimate: 60%; the middle value lies beyond the limit too.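

In this assay, hydrogen in place of methyl on the aromatic nitrogen gives an at least 1.4-fold higher number from compound 3 to compound 4 (0.15 log units; that floor lies within the scatter), so this position now has a direct reading, though that reading does not establish an effect of the methyl. The step from compound 2 to compound 4 cannot be read, as both values are limits. The set now sits mostly at one boundary: the limit of > 100000 nM in this assay, at which 3 of the 4 values shown sit.

Going by these compounds, whether a longer chain or an amine on that aromatic nitrogen would give a lower number than compound 3 stays open.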